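Methylsulfanyl in place of butyl: a forecast for compound 4

A few compounds are considered here, and "the series" means these few. Any claim that something is new, unique, unknown or untested is made for them only; others in the source may bear on it.

Compound 1 `CCCc1ccc(-c2cc(=O)c3c(o2)C(CC)(CC)C(=O)C(CC)=C3O)cc1`: 12.2 uM
Compound 2 `CCCCc1ccc(-c2cc(=O)c3c(o2)C(CC)(CC)C(=O)C(CC)=C3O)cc1`: 37 uM
Compound 3 `CCC1=C(O)c2c(oc(-c3ccc(CC(C)C)cc3)cc2=O)C(CC)(CC)C1=O`: 17.4 uM

Three compounds sharing one core were tested in a functional assay on KBVIN cells (Homo sapiens) for antiproliferative activity, read by sulforhodamine B assay, with a stated time of 3 days; a lower number here means that less compound is needed, a higher number that more compound is needed for the effect. Compound 2 gives the highest number of the three: the step of a 3.0-fold higher number from compound 1 to compound 2 (0.48 log units; beyond the scatter) and the step of a 2.1-fold lower number from compound 2 to compound 3 (0.33 log units; beyond the scatter) both set it apart beyond the scatter, while compound 1 and compound 3 lie within the scatter of each other, as a 1.4-fold higher number from compound 1 to compound 3 (0.15 log units; within the scatter) shows. The untested compound 4 `CCC1=C(O)c2c(oc(-c3ccc(SC)cc3)cc2=O)C(CC)(CC)C1=O` differs from compound 2 in one place: methylsulfanyl in place of butyl on an aromatic carbon. Both measured steps at that aromatic carbon bear on this change, and both show the butyl of compound 2 carrying the highest number, with the propyl of compound 1 giving a modestly lower one. A shift towards a lower number in this assay is therefore expected for compound 4, roughly a 2.5-fold lower number from compound 2 to compound 4 (0.39 log units; beyond the scatter). Compound 4 is estimated at 15 uM, within 5 uM to 45 uM.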

Compound 4, concentration for half-maximal effect: 1.38 uM
For compound 4 the middle estimate is 11-fold (1.04 log units) above the measured one; the whole stated range lies above it.
By their numbers in this assay, from the lowest: compound 4; then compounds 1 and 3 (each within the scatter of the next); then compound 2.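

In this assay, methylsulfanyl on this aromatic carbon, para to a large group, gives a far lower number than any of the three alkyl chains: a 27-fold lower number from compound 2 to compound 4 (1.43 log units; beyond the scatter), a 13-fold lower number from compound 3 to compound 4 (1.10 log units; beyond the scatter) and an 8.8-fold lower number from compound 1 to compound 4 (0.95 log units; beyond the scatter). The differences among propyl, butyl and isobutyl gave no sign of a shift of this size at this position. Nothing measured here accounts for the gain.

The compounds shown cannot tell whether the sulfur atom or the short length of the group matters more. A methoxy or an ethylsulfanyl group at this carbon would separate the two.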